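The source may report more compounds than this note shows. Statements on the series, on what has been measured and on what is new or still open speak of the compounds shown alone.

Measured in a functional assay on MES-SA cells (Homo sapiens) for cytotoxicity, read by luminescence and CellTiter-Glo, with a stated time of 72 h; a higher number here means a weaker inhibitor, a lower number a stronger inhibitor:
- Compound 1 `COC[C@H](NC(=O)c1cc(C)on1)C(=O)N[C@@H](CC(C)C)C(=O)N[C@@H](CC(C)C)C(=O)[C@@]1(C)CO1`: 45 nM
- Compound 2 `COC[C@H](NC(=O)c1cc(C)on1)C(=O)N[C@@H](COC)C(=O)N[C@@H](CC(C)C)C(=O)[C@@]1(C)CO1`: 22 nM

Of these two, compound 2 has the lower number and so is the stronger inhibitor. Compound 3 `COC[C@H](NC(=O)c1cc(C)on1)C(=O)N[C@H](C(=O)N[C@@H](CC(C)C)C(=O)[C@@]1(C)CO1)C(C)C` has not yet been measured in this assay. It differs from compound 2 as follows: isopropyl in place of methoxymethyl on a saturated chain carbon bound to an amide-type nitrogen and a carbonyl carbon. In words, this is isopropyl in place of methoxymethyl on a saturated chain carbon bound to an amide-type nitrogen and a carbonyl carbon.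

Among the measured compounds shown here, only one measured step bears on this change: a 2.0-fold lower number from compound 1 to compound 2 (0.31 log units; beyond the scatter). It was modest and put methoxy in place of isopropyl. That step is not the exact reverse of this one, so it guides mainly the direction. A small move to a higher number is expected, possibly no larger than the scatter. The expected change is a 1.8-fold higher number from compound 2 to compound 3 (0.26 log units; within the scatter). For compound 3 the estimated value is 40 nM, with an expected range of 15 nM to 100 nM.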

Compound 3, half-maximal inhibitory concentration in the MES-SA assay: 57 nM
Compound 3: the middle estimate sits 1.4-fold (0.15 log units) below what was measured; the range from low to high includes it.
By their numbers in the MES-SA assay, from the lowest: compound 2; then compounds 1 and 3 (each within the scatter of the next).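

In the MES-SA assay, the result gives a 2.6-fold higher number from compound 2 to compound 3 (0.41 log units; beyond the scatter), so methoxymethyl at this saturated chain carbon now stands ahead of both isobutyl and isopropyl. Swapping between those two groups at the same carbon gives only a 1.3-fold higher number from compound 1 to compound 3 (0.10 log units; within the scatter), so the two cannot be told apart here. In a physicochemical assay for metabolic stability, in simulated intestinal fluid, with a stated time of 15 min, tested at 4 uM (on this read-out lower numbers stand for a less stable compound and higher numbers for a more stable compound), compound 2 gives 70% and compound 3 gives 95%, so the same change from methoxymethyl to isopropyl runs the other way, and the weaker inhibitor of this pair is the more stable compound: the measured percent of the compound remaining of compound 2, 70%, and of compound 3, 95%, a number 25 percentage points higher (beyond the scatter)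

On these data alone, whether another group at this carbon, such as hydroxymethyl or a longer ether chain like ethoxymethyl, could combine the stronger inhibition of compound 2 with the stability of compound 3 stays open. One pair also cannot show whether this trade-off holds for other groups.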